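This account rests on a few compounds, and the source may have more. Where it says the series, first, only, none or still open, it means among the compounds named here.

In a physicochemical assay for lipophilicity, measured as octanol-water partition (a higher number here means a more lipophilic compound, a lower number a more polar compound), compound 2 `CCCc1cn(C/C=C(\C)CCC=C(C)C)nn1` gives 4.5, which places it between compound 3 `CCCc1cn(C/C=C(/C)CCC=C(C)C)nn1` at 4.05 and compound 1 `CC(C)=CCC/C(C)=C/CC/C(C)=C/Cn1cc(-c2ccccc2)nn1` at 6.95. Compound 4 `CC(C)=CCC/C(C)=C/Cn1cc(-c2ccccc2)nn1` departs from compound 2 by phenyl in place of propyl on an aromatic carbon, with phenyl in place of propyl on an aromatic carbon. Within the data shown here, the only measured step, a number 0.45 log units lower from compound 2 to compound 3 (beyond the scatter), goes with the fact that compounds 2 and 3 differ only in the configuration as drawn, so it offers no direct measure of exchanging one group for another. The nearest guide is compound 1, which also carries phenyl and gives 6.95, the top of the range so far. A modest rise in this assay is therefore expected, with a number 0.80 log units higher from compound 2 to compound 4 (beyond the scatter) as the estimate. Compound 4 is expected at 5.3, within an estimated range of 4.8 to 5.8.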

Compound 4, partition coefficient: 4.91
Compound 4: middle estimate off by 0.39 log units, on the high side, within the range that was stated.
By their numbers in this assay, from the lowest: compound 3; then compound 2; then compound 4; then compound 1.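

In this assay, among these compounds, the exchange of propyl for phenyl on an aromatic carbon gives a number 0.41 log units higher from compound 2 to compound 4 (beyond the scatter) and is the first direct reading of a group change at this position. Hydrogen in place of 3-methylbut-2-en-1-yl on a saturated chain carbon bound to a double-bonded chain carbon gives a number 2.04 log units lower from compound 1 to compound 4 (beyond the scatter) and so is a large step beside that modest one. Nothing available here gives a cause for either step. Still open, going by these compounds, is how an amine or a carboxylic acid on that aromatic carbon would read in this assay and whether the phenyl step would hold with the double bond drawn Z.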